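The compounds below may be only part of what the source reports. "The series", "measured", "known", "first", "only" and "open" are said of these compounds alone.

Working notes on the series: in a functional assay on HepG2 cells (Homo sapiens) for inhibition, read by MTT assay (on this read-out higher numbers stand for weaker inhibition of growth and lower numbers for stronger inhibition of growth), compound 1 `COc1cc2oc(-c3cccc(NC(=O)c4cccc(C#N)c4)c3)cc(=O)c2c(OC)c1OC` gives 11900 nM and compound 2 `COc1cccc(C(=O)Nc2cccc(-c3cc(=O)c4c(OC)c(OC)c(OC)cc4o3)c2)c1` gives 7060 nM, so the two stand within the scatter of each other. Within the data shown here, the only measured step, a 1.7-fold lower number from compound 1 to compound 2 (0.23 log units; within the scatter), is methoxy in place of cyano on an aromatic carbon. Among the measured compounds shown here, it lies within the scatter, and no measured step covers a shift of the methoxy group itself. Compound 3 `COc1ccccc1C(=O)Nc1cccc(-c2cc(=O)c3c(OC)c(OC)c(OC)cc3o2)c1` is the next case: 2-methoxyphenyl in place of 3-methoxyphenyl on a carbonyl carbon. In short, it has 2-methoxyphenyl in place of 3-methoxyphenyl on a carbonyl carbon, with the same atoms joined differently. For the measured compounds named here, with only that small step as a guide, no change beyond the scatter is expected in this assay, and no direction can be set. The expected step is a 1.1-fold higher number from compound 2 to compound 3 (0.05 log units; within the scatter). The estimate for compound 3 is 8000 nM, with an expected range of 3000 nM to 20000 nM.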

Compound 3, concentration for 50% growth inhibition: 7530 nM
Beside the measured number, compound 3's estimate is 1.1-fold (0.03 log units) above it; low and high end bracket the measured number.
By their numbers in this assay, from the lowest: compounds 2, 3 and 1 (each within the scatter of the next).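

In this assay, among these compounds, 2-methoxyphenyl in place of 3-methoxyphenyl on the carbonyl carbon gives a 1.1-fold higher number from compound 2 to compound 3 (0.03 log units; within the scatter), so a shift of the methoxy group, which no earlier step covered, is now measured and stays within the scatter. The change of 3-cyanophenyl to 2-methoxyphenyl at the same place gives a 1.6-fold lower number from compound 1 to compound 3 (0.20 log units; within the scatter) and also stays within the scatter, so the three groups tested on this carbonyl carbon cannot be told apart on this read-out. No supporting measurement bears on these results.

Left open is whether a different group on this phenyl ring, such as an amine or a carboxylic acid, or a longer chain in place of methoxy, would move the number beyond the scatter. Also open, on these data alone, is whether changes to the amide link or to the methoxy groups of the shared core would do so.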